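Chloro substitution on the aryl hydrazone series: cytotoxicity notes

The compounds below may be only part of what the source reports. "The series", "measured", "known", "first", "only" and "open" are said of these compounds alone.

Measured so far:
compound 1, `Cn1nnnc1SCC(=O)N/N=C/c1ccccc1`: 9700000 nM
compound 2, `Cn1nnnc1SCC(=O)N/N=C/c1ccc(Cl)cc1`: 2100000 nM
compound 3, `C/C(=N\NC(=O)CSc1nnnn1C)c1cccc(Cl)c1`: 3400000 nM

In an ADME assay on NIH3T3 cells (Mus musculus) for cytotoxicity, read by XTT assay, with a stated time of 24 h (a higher number here means a weaker inhibitor, a lower number a stronger inhibitor), compound 1 gives 9700000 nM and compound 2 gives 2100000 nM. Going by the values given here, the step of a 4.6-fold lower number from compound 1 to compound 2 (0.66 log units; beyond the scatter) is the one change measured in this set: chloro in place of hydrogen on an aromatic carbon. Compound 3 in this assay gives 3400000 nM; against compound 2 its value lies within the scatter, against compound 1 it is a lower number beyond the scatter. The difference between the core of compound 3 and the core of compound 1 is not broken down here.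

Compound 4, `C/C(=N\NC(=O)CSc1nnnn1C)c1cc(Cl)ccc1Cl`, has not yet been run in this assay. It differs from compound 3 by chloro in place of hydrogen on an aromatic carbon. Among the compounds with values here, this is the same kind of change as the one from compound 1 to compound 2, not the same change: the earlier chloro enters "para to a large group", whereas the new one enters "ortho to a large group; para to a chloro group", onto a ring that already carries a chloro.

For compound 4 a lower number than compound 3 is expected, and the step of a 2.8-fold lower number from compound 3 to compound 4 (0.45 log units; beyond the scatter) is estimated to be somewhat smaller than the one measured, because a 4.6-fold lower number from compound 1 to compound 2 (0.66 log units; beyond the scatter) was obtained on a ring without a chloro and at a different place, and compound 3 already starts at a lower number than compound 1. The estimate for compound 4 in this assay is 1200000 nM, with a range from 400000 nM to 3500000 nM, resting on a single measured step of this kind.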

Compound 4, half-maximal inhibitory concentration: 1000000 nM
Compound 4: middle estimate off by 1.2-fold (0.08 log units), on the high side; the measured number falls inside the stated range.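

In this assay, chloro in place of hydrogen on an aromatic carbon again gives a lower number, with a 3.4-fold lower number from compound 3 to compound 4 (0.53 log units; beyond the scatter) for the entry ortho to a large group and para to a chloro group, on a ring that already carries a chloro. Set beside the earlier step, the change carries over in direction and in size from one core to the other: the same change on two cores in this assay, a 4.6-fold lower number (0.66 log units; beyond the scatter) from compound 1 to compound 2 and a 3.4-fold lower number (0.53 log units; beyond the scatter) from compound 3 to compound 4, 1.4-fold (0.13 log units) apart, within the scatter of two such steps

Within these two pairs, then, neither the different core nor the chloro already on the ring of compound 3 produces a step distinguishable from the first, but this rests on only two steps, and the core, the place of entry and the chloro already present all change together between them, so no one of these can be judged on its own, and a small influence from any of them could lie hidden within the scatter. Nothing here extends the result to other cores or to other assays.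

Still open, going by these compounds, is whether an amine, a carboxylic acid or a trifluoromethyl entering at the same places would give steps of similar size, or whether the steps belong to chloro alone. Also open, on these data alone, is whether a further chloro on the ring of compound 4 would lower the number again.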